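The source may report more compounds than this note shows. Statements on the series, on what has been measured and on what is new or still open speak of the compounds shown alone.

Of the compounds shown here, three have been measured in a functional assay on the whole organism for antagonist activity, with Mus musculus as the target; a lower number here means that less compound is needed, a higher number that more compound is needed for the effect. Compound 1 `CCC(=O)N(c1ccc(Cl)cc1)C1CCCCC1N(C)C` gives 17 mg/kg in this assay. Compound 2 `CCC(=O)N(c1ccc(C)cc1)C1CCCCC1N(C)C` gives only > 50 mg/kg, which is a limit of the assay and not a number, namely (the limit of > 50 mg/kg in this assay, at which 1 of the 3 values shown sits). Compound 3 `CCC(=O)N(c1ccccc1C)C1CCCC1N(C)C` differs from compound 2 in a way that is not broken down here. Compound 3 gives 5 mg/kg in this assay, the lowest of the two numbers obtained, with compound 1 the nearest.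

Compound 1 and compound 2 differ in one place: chloro in place of methyl on an aromatic carbon. As far as these compounds go, this change gave an at least 2.9-fold lower number from compound 2 to compound 1 (0.46 log units; beyond the scatter), a step whose true size stays open, one end of it being a limit.

Compound 4 `CCC(=O)N(c1ccccc1Cl)C1CCCC1N(C)C` has not yet been measured. It differs from compound 3 by chloro in place of methyl on an aromatic carbon. This is the same kind of change as that from compound 2 to compound 1, but not the same change: there the chloro sits para to a large group, here ortho to a large group. Because the earlier step of an at least 2.9-fold lower number from compound 2 to compound 1 (0.46 log units; beyond the scatter) pointed toward a lower number, compound 4 is also expected to give a lower number than compound 3. The step is estimated as a 1.7-fold lower number from compound 3 to compound 4 (0.22 log units; within the scatter), held smaller than the earlier one in view of the changed place and the limit at one end of that earlier step. Compound 4 is therefore expected to give about 3 mg/kg, within a range from 1.2 mg/kg to 8 mg/kg.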

Compound 4, dose for half-maximal effect: 2 mg/kg
For compound 4 the middle estimate is 1.5-fold (0.18 log units) above the measured one; the range from low to high includes it.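

In this assay, chloro in place of methyl on an aromatic carbon, ortho to a large group, gave a 2.5-fold lower number from compound 3 to compound 4 (0.40 log units; beyond the scatter), which makes this the second core on which the swap lowered the number. Set side by side, the two steps point the same way, so the direction of the change carried over between these two cores, even though the chloro does not sit in the same place on the ring in the two pairs: the same change on two cores in this assay, an at least 2.9-fold lower number (0.46 log units; beyond the scatter) from compound 2 to compound 1 and a 2.5-fold lower number (0.40 log units; beyond the scatter) from compound 3 to compound 4; the limit leaves it open whether they differ. Two pairs do not show that the step has the same size on both cores, and they say nothing about any other core; compound 2 gives > 50 mg/kg, which is a limit of the assay and not a number.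

The compounds shown leave open how other groups would behave at this place on the ring, such as fluoro, methoxy or trifluoromethyl, and so whether chloro is better than its close relatives or simply better than methyl. They also leave open whether the swap would still lower the number with a longer acyl chain on the amide, or with a primary amine in place of the dimethylamino group.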